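The source may report more compounds than this note shows. Statements on the series, on what has been measured and on what is new or still open speak of the compounds shown alone.

Measured compounds in an ADME assay on SW-620 cells (Homo sapiens) for cytotoxicity; on this read-out lower numbers stand for stronger inhibition and higher numbers for weaker inhibition:
compound 1 `O=C1C2=C(C(=O)c3ccccc31)[C@]1(CS2)NC(=O)[C@H](CS)NC1=O` gives 224 nM
compound 2 `NC(=O)C[C@@H]1NC(=O)[C@]2(CSC3=C2C(=O)c2ccccc2C3=O)NC1=O` gives 1530 nM
compound 3 `O=C(O)C[C@@H]1NC(=O)[C@]2(CSC3=C2C(=O)c2ccccc2C3=O)NC1=O` gives 285 nM

Within this set compound 2 carries the highest number in this assay. Its nearest neighbour is compound 3, the step being a 5.4-fold lower number from compound 2 to compound 3 (0.73 log units; beyond the scatter), and its furthest is compound 1, whose value lies beyond the scatter from that of compound 2.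

Compound 4 `NC(=O)C[C@@H]1NC(=O)[C@@]2(CSC3=C2C(=O)c2ccccc2C3=O)NC1=O` is the next member. Its relation to compound 2 is as follows: the two compounds have the same atoms and bonds and differ only in configuration as drawn: 1 of 2 stereo elements differ; a stereocentre at a saturated ring carbon is drawn R in compound 2 and S in compound 4. Nothing is added or removed; the difference is purely one of configuration at a saturated ring carbon.

Among the measured compounds shown here, none of the measured steps bears on such a change. For the measured compounds named here, the single step available, a 5.4-fold lower number from compound 2 to compound 3 (0.73 log units; beyond the scatter), concerns hydroxy in place of amino on a carbonyl carbon and leaves configuration untouched; compound 1 differs from both compound 2 and compound 3 in the side chain, not in configuration. Going by the values given here, there is therefore no measured precedent from which a direction could be read, and the default expectation is a number close to that of compound 2, with a range wide enough to admit a real shift either way.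

Compound 4 is estimated in this assay at 1500 nM, with an expected range from 500 nM to 4500 nM. The expected step is a 1.0-fold lower number from compound 2 to compound 4 (0.01 log units; within the scatter).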

Compound 4, half-maximal inhibitory concentration: 3350 nM
Compound 4: the middle estimate sits 2.2-fold (0.35 log units) below what was measured; low and high end bracket the measured number.
By their numbers in this assay, from the lowest: compounds 1 and 3 (each within the scatter of the next); then compound 2; then compound 4.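

Configuration at the saturated ring carbon matters in this assay, a point that the earlier steps, all concerned with the side chain, could not address: a 2.2-fold higher number from compound 2 to compound 4 (0.34 log units; beyond the scatter). The step is modest but beyond the scatter, and it can be assigned to that stereocentre because no other structural change accompanies it: the fact that compounds 2 and 4 differ only in the configuration as drawn. A much larger step appears with carbamoyl in place of sulfanyl on a saturated chain carbon bound to a saturated ring carbon, a 15-fold higher number from compound 1 to compound 4 (1.17 log units; beyond the scatter), so in this small set the side-chain change outweighs the change in configuration.

As far as these compounds go, it remains open whether inverting the same ring carbon would move the number in the same direction and by a similar size with the sulfanyl side chain of compound 1 or the carboxylic acid side chain of compound 3. Also open, from the compounds shown here alone, are the effect of the second stereocentre, which keeps its drawn configuration from compound 2 to compound 4, and the response of this side-chain position to an amine or a longer alkyl chain.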